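Swapping the charged chain end on a fibrosis reporter series

A few compounds are considered here, and "the series" means these few. Any claim that something is new, unique, unknown or untested is made for them only; others in the source may bear on it.

Measured so far:
compound 1, `Cc1cc(OCCCCCCC[N+]23CCN(CC2)CC3)cc(-n2cc(C(=O)Nc3cc(F)cc(F)c3)c(=O)c3ccc(N(C)C)nc32)c1`, 10.3%
compound 2, `CN(C)c1ccc2c(=O)c(C(=O)Nc3cc(F)cc(F)c3)cn(-c3ccc(OCCCCCCC[N+](C)(C)C4CCCCC4)c(Cl)c3)c2n1`, 34.8%

In an assay on LX2 cells for inhibition of COL1A1 promoter (Homo sapiens), read by a luciferase reporter, with a stated time of 24 h, tested at 20 uM (on this read-out lower numbers stand for a weaker effect and higher numbers for a stronger effect at the one concentration tested), compound 1 gives 10.3%, the lowest of the two numbers; compound 2 sits a good deal higher, beyond the usual scatter. Among the measured compounds shown here, compound 2 differs from compound 1 in more than one place, so the two values show only that the pair spans a real gap, not which change causes it.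

Compound 3, `Cc1cc(OCCCCCCC[N+](C)(C)C2CCCCC2)cc(-n2cc(C(=O)Nc3cc(F)cc(F)c3)c(=O)c3ccc(N(C)C)nc32)c1`, has not yet been measured. It differs from compound 1 by a group of 9 heavy atoms (8 carbon, 1 nitrogen; one six-membered non-aromatic ring of carbon only) in place of a group of 8 heavy atoms (6 carbon, 2 nitrogen; 2 six-membered non-aromatic rings with 2 hetero atoms each), on a saturated chain carbon, seven bonds along the chain from an oxygen on an aromatic ring. For the measured compounds named here, no measured pair isolates exactly this change, so the expectation rests on the gap between compound 1 and compound 2.

Compound 3 is expected to give 25% in this assay, with a range from 8% to 45%. The expected step of a number 14.7 percentage points higher from compound 1 to compound 3 (beyond the scatter) is an upward one that may only just clear the scatter, because compound 2 reaches 34.8% while compound 1 stays at 10.3%.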

Compound 3, a percentage reported as inhibition, at one concentration (the size of the read-out at that concentration, not a potency): 52.5%
Estimate against measurement, compound 3: 27.5 percentage points below; the whole stated range lies below it.
By their numbers in this assay, from the lowest: compound 1; then compound 2; then compound 3.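

With the rest of the molecule unchanged, this assay shows a number 42.2 percentage points higher from compound 1 to compound 3 (beyond the scatter) when the group with 2 six-membered non-aromatic rings gives way to the group with one six-membered non-aromatic ring of carbon only. This ties a large change to the end of the chain alone, which the earlier pair could not do, since compound 1 and compound 2 differ in more than one place; both groups carry a net charge of +1, so the step arises with that charge unchanged. Nothing available explains why this swap changes the read-out.

A trimethylammonium or a piperidinium end on the same chain would test whether the ring of carbon only carries the gain. A longer chain would test how much the distance from the oxygen counts.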